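Nitro in Place of Nitrile on a Ret Kinase Inhibitor

This account rests on a few compounds, and the source may have more. Where it says the series, first, only, none or still open, it means among the compounds named here.

Compound 1, `CC(=O)N1CCc2[nH]c(/C=C3\C(=O)Nc4ccc(OC(C)C)cc43)cc2C1`: 150 nM
Compound 2, `CC(=O)N1CCc2[nH]c(/C=C3\C(=O)Nc4ccc(C#N)cc43)cc2C1`: 4 nM

Among the measured compounds shown here, in an assay on isolated protein for inhibition of proto-oncogene tyrosine-protein kinase receptor Ret (Homo sapiens) (on this read-out higher numbers stand for weaker inhibition and lower numbers for stronger inhibition), compound 2 gives the lowest of the two numbers, and the one step measured so far, a 38-fold lower number from compound 1 to compound 2 (1.57 log units; beyond the scatter), shows how much the group on that aromatic carbon matters. Compound 3, `CC(=O)N1CCc2[nH]c(/C=C3\C(=O)Nc4ccc([N+](=O)[O-])cc43)cc2C1`, carries nitro in place of cyano on an aromatic carbon. For the measured compounds named here, no measured pair exchanges these two groups, so the expectation rests only on compound 2 and its value 4 nM. The expected step of a 1.5-fold higher number from compound 2 to compound 3 (0.18 log units; within the scatter) is small, and compound 3 is therefore estimated at 6 nM, between 2 nM and 25 nM.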

Compound 3, half-maximal inhibitory concentration: 73 nM
Compound 3: middle estimate off by 12-fold (1.09 log units), on the low side; the measured number lies above the stated range.
By their numbers in this assay, from the lowest: compound 2; then compound 3; then compound 1.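

Nitrile and nitro are not interchangeable on this aromatic carbon: the exchange brings an 18-fold higher number from compound 2 to compound 3 (1.26 log units; beyond the scatter) and removes most of what the nitrile gained over isopropoxy. The nitro group keeps only part of that gain, with a 2.1-fold lower number from compound 1 to compound 3 (0.31 log units; beyond the scatter) still separating it from the isopropoxy group. Nothing available explains why these two groups differ so much.

Going by these compounds, how an amide, a carboxylic acid or a single fluorine atom would fare on this carbon stays open. So does whether the nitrile keeps its advantage once another part of the shared core changes.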